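Working notes: hydroxypropyl to ethoxyethyl on the shared core

The compounds below may be only part of what the source reports. "The series", "measured", "known", "first", "only" and "open" are said of these compounds alone.

Measured so far:
compound 1, `CCCn1c(=O)n(C)c(=O)c2c1ncn2CCC(=O)O`: > 200000 nM
compound 2, `CCCn1c(=O)n(C)c(=O)c2c1ncn2CCCO`: 112000 nM
compound 3, `CCCn1c(=O)n(C)c(=O)c2c1ncn2CCOCC`: not yet measured

In an assay on Cerebral cortex for binding affinity to adenosine receptor A1 (Cavia porcellus), read by radioligand binding (on this read-out lower numbers stand for stronger inhibition and higher numbers for weaker inhibition), compound 2 gives 112000 nM, the only true number shown; it stands alone among the measured values. For compound 1 this assay reports only a limit, > 200000 nM. Among the compounds with values here, the single measured step is an at least 1.7-fold lower number from compound 1 to compound 2 (0.25 log units; that floor lies within the scatter), and its size cannot be pinned down because it rests on (the limit of > 200000 nM in this assay, at which 1 of the 2 values shown sits).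

Compound 3 differs from compound 2 by ethoxy in place of hydroxymethyl on a saturated chain carbon, two bonds along the chain from an aromatic nitrogen. Within the data shown here, the one measured step sits at the same place on the chain but swaps a different pair of groups, carboxy for hydroxymethyl, and reaches only a floor that lies within the scatter; it therefore says little about the size of the present step. Both measured values are weak in this assay, and nothing shown argues for a move beyond the scatter in either direction.

Compound 3 is therefore expected near compound 2, estimated at 90000 nM with a range of 25000 nM to 300000 nM. The expected step is a 1.2-fold lower number from compound 2 to compound 3 (0.09 log units; within the scatter).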

Compound 3, inhibition constant: 24300 nM
Compound 3: middle estimate off by 3.7-fold (0.57 log units), on the high side; the measured number lies below the stated range.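

In this assay, within the data shown here, ethoxy in place of hydroxymethyl on this saturated chain carbon gives a 4.6-fold lower number from compound 2 to compound 3 (0.66 log units; beyond the scatter), the first step with a fully readable size and one that lies beyond the scatter. The chain end at this place therefore affects the read-out, although the change swaps a group bearing a hydrogen-bond donor for one without and also adds to the heavy atoms, and these two differences travel together in this single pair. Against carboxy at the same place, the change gives an at least 8.2-fold lower number from compound 1 to compound 3 (0.91 log units; beyond the scatter), which is only a floor, and its true size cannot be read because compound 1 stands at a limit: the limit of > 200000 nM in this assay, at which 1 of the 3 values shown sits.

On these data alone, the pair does not separate the loss of the hydroxyl hydrogen from the longer chain, so it remains open whether a methoxy group, a propoxy group or a plain alkyl chain of similar length would follow compound 3 in this assay. As far as these compounds go, how an amine at the chain end would read here also remains open, as does whether the step carries over to any other core.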